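Swapping a Hydroxyl for a Methoxy on the Cyclohexyl Ring

The source may hold more compounds than are shown below. What is called first, only, known or untested is meant among the compounds shown, and "the series" means these compounds.

Compound 1 `Nc1ncnc2c1c(Oc1cc(C(F)(F)F)ccn1)nn2[C@@H]1CCCC[C@H]1O`: > 2.41 h
Compound 2 `Nc1ncnc2c1c(Oc1cc(C(F)(F)F)ccn1)nn2C1CC1`: > 2.41 h

In an ADME assay on microsomes from liver (Homo sapiens) for metabolic stability, read by LC-MS, using NADPH, with a stated time of 10 min, tested at 10 uM (on this read-out lower numbers stand for a shorter-lived compound and higher numbers for a longer-lived compound), compound 1 gives > 2.41 h, which is a limit of the assay rather than a number. Compound 2 gives > 2.41 h, likewise a limit. The step that the two limits leave unreadable from compound 1 to compound 2 therefore cannot be read. Compound 3 `CO[C@H]1CC[C@H](n2nc(Oc3cc(C(F)(F)F)ccn3)c3c(N)ncnc32)CC1` differs from compound 1 in one place: 4-methoxycyclohexyl in place of 2-hydroxycyclohexyl on an aromatic nitrogen. Going by the values given here, the only measured step at this position is the one from compound 1 to compound 2, and both its values sit at the limit of > 2.41 h in this assay, at which 2 of the 2 values shown sit. Compound 3 is therefore expected to sit at that limit as well, with an estimated half-life of 2.6 h and a range of 1.2 h to 5.5 h. The step that the limit leaves unreadable from compound 1 to compound 3 is expected to stay within the usual scatter.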

Compound 3, half-life: > 2.41 h
Compound 3: a limit, no number; the forecaster's own chance of this, stated with the estimate: 75%; the middle value does not contradict the limit.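

Compound 3 sits at the same limit as compound 1 and compound 2, so no step among them can be read: the limit of > 2.41 h in this assay, at which 3 of the 3 values shown sit.

Going by these compounds, what stays open is each compound's true half-life, and whether these groups on the aromatic nitrogen differ at all.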